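Ring-nitrogen aryl group: compound 3 to compound 4

The source may hold more compounds than are shown below. What is called first, only, known or untested is meant among the compounds shown, and "the series" means these compounds.

In a functional assay on A549 cells (Homo sapiens) for antiproliferative activity, read by MTT assay, with a stated time of 72 h (on this read-out higher numbers stand for weaker inhibition and lower numbers for stronger inhibition), compound 3 `O=C1COc2ccc(-c3cnc(Cl)c(NS(=O)(=O)c4ccc(F)cc4)c3)cc2N1` gives > 40000 nM, which is a limit of the assay and not a number. With an aryl group on the ring nitrogen, numbers are obtained: compound 1 `COc1cccc(N2C(=O)COc3ccc(-c4cnc(Cl)c(NS(=O)(=O)c5ccc(F)cc5)c4)cc32)c1` reads 32700 nM and compound 2 `O=C1COc2ccc(-c3cnc(Cl)c(NS(=O)(=O)c4ccc(F)cc4)c3)cc2N1c1ccc(F)cc1` reads 22300 nM.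

Compound 4 `O=C1COc2ccc(-c3cnc(Cl)c(NS(=O)(=O)c4ccc(F)cc4)c3)cc2N1c1ccc(Cl)cc1` has 4-chlorophenyl in place of hydrogen on an amide-type nitrogen in a ring. Going by the values given here, two measured steps bear on this change when read backwards: an at least 1.7-fold higher number from compound 2 to compound 3 (0.25 log units; that floor lies within the scatter) and an at least 1.2-fold higher number from compound 1 to compound 3 (0.08 log units; that floor lies within the scatter). From the compounds shown here alone, both are floors within the scatter, so the real size of removing the aryl group stays unknown. Exchanging one aryl group for the other gave a 1.5-fold lower number from compound 1 to compound 2 (0.17 log units; within the scatter), so compound 2, with its 4-fluorophenyl group, serves as the closest guide at 22300 nM.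

A modest move towards a lower number is therefore expected in this assay. The expected step is an at least 1.8-fold lower number from compound 3 to compound 4 (0.25 log units; that floor lies within the scatter). For compound 4 the estimated value is 22000 nM, with an expected range of 11000 nM to 40000 nM.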

Compound 4, half-maximal inhibitory concentration: 21600 nM
Estimate against measurement, compound 4: 1.0-fold (0.01 log units) above; the measured number falls inside the stated range.
By their numbers in this assay, from the lowest: compounds 4, 2 and 1 (each within the scatter of the next). At a limit, above all of these: compound 3.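

In this assay, chloro in place of fluoro on an aromatic carbon gives a 1.0-fold lower number from compound 2 to compound 4 (0.01 log units; within the scatter), and 4-chlorophenyl in place of 3-methoxyphenyl on the amide-type nitrogen in a ring gives a 1.5-fold lower number from compound 1 to compound 4 (0.18 log units; within the scatter). Compounds 1, 2 and 4 are therefore not told apart, so neither the halogen nor the 3-methoxyphenyl group separates these three aryl groups at this position. For 4-chlorophenyl in place of hydrogen, the step is an at least 1.8-fold lower number from compound 3 to compound 4 (0.26 log units; that floor lies within the scatter), which is only a floor, as the value for compound 3 is a limit of the assay and not a number: the limit of > 40000 nM in this assay, at which 1 of the 4 values shown sits.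

Still open, from the compounds shown here alone, is how this nitrogen reads with a group other than a directly attached phenyl ring, such as a benzyl group, an aminoethyl chain or a carboxylic acid on a short chain. Going by these compounds, the real size of the step from hydrogen to an aryl group also remains open.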